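The compounds below may be only part of what the source reports. "The series", "measured", "known", "first", "only" and "open" are said of these compounds alone.

Working notes on the series. Three compounds have been run in a functional assay on CHO cells for positive allosteric modulation of metabotropic glutamate receptor 2 (Homo sapiens), read by GTPgammaS binding, with a stated time of 30 min; on this read-out lower numbers stand for smaller maximal responses and higher numbers for larger maximal responses. Compound 1 `CCCc1cnc2c(C#N)c(N3CCC(c4ccccc4)CC3)ccn12` gives 254%, compound 2 `CCCc1nnc2c(C#N)c(N3CCC(c4ccccc4)CC3)ccn12` gives 272%, and compound 3 `N#Cc1c(N2CCC(c3ccccc3)CC2)ccn2c(CC(F)(F)F)cnc12` gives 259%. Compound 3 carries trifluoromethyl in place of ethyl on a saturated chain carbon bound to an aromatic carbon relative to compound 1, and this change gives a number 5 percentage points higher from compound 1 to compound 3 (within the scatter). Compound 1 and compound 2 share the side chain and the nitrile-bearing part but differ in their cores; how the two cores differ is not broken down here. Compound 2 stands highest of the three in this assay, its separation from compound 3 and from compound 1 lying beyond the scatter in both cases.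

Compound 4 `N#Cc1c(N2CCC(c3ccccc3)CC2)ccn2c(CC(F)(F)F)nnc12` has not yet been measured. Against compound 2 it shows (trifluoromethyl in place of ethyl on a saturated chain carbon bound to an aromatic carbon), the same change that separates compound 3 from compound 1, made on the core of compound 2. Because the earlier change gave a number 5 percentage points higher from compound 1 to compound 3 (within the scatter), a step of similar size is expected here, a number 4 percentage points higher from compound 2 to compound 4 (within the scatter), with compound 2 as the starting point. On that basis compound 4 is expected to give about 276% in this assay, between 255% and 298%.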

Compound 4, largest response reached (Emax), in percent of the reference or control that the assay uses: 277%
The estimate for compound 4 lay 1 percentage points below the measured number; low and high end bracket the measured number.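

In this assay, trifluoromethyl in place of ethyl on a saturated chain carbon bound to an aromatic carbon gives a number 5 percentage points higher from compound 2 to compound 4 (within the scatter), and set beside the earlier step, the change carries over from one core to the other with no visible difference in size: the same change on two cores in this assay, a number 5 percentage points higher (within the scatter) from compound 1 to compound 3 and a number 5 percentage points higher (within the scatter) from compound 2 to compound 4, 0 percentage points apart, within the scatter of two such steps. Both steps lie within the scatter, so the pairs show that the maximal response cannot be told apart before and after the change on these two cores, not that the change raises it. Two cores are a small sample, and these pairs say nothing about how the change would behave on a further core or in another read-out.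

The side chain and the nitrile stay the same throughout, and only propyl and 2,2,2-trifluoroethyl appear at the changed place. Going by these compounds, how a longer chain, an amine or a carboxylic acid at that place would compare in this read-out remains open, as does the effect of replacing the nitrile.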